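Notes on the 2-chlorophenyl exchange in the series

The compounds below may be only part of what the source reports. "The series", "measured", "known", "first", "only" and "open" are said of these compounds alone.

Measured in a functional assay on HepG2 cells (Homo sapiens) for antiproliferative activity, read by MTT assay, with a stated time of 24 h; a lower number here means a stronger inhibitor, a higher number a weaker inhibitor:
- compound 1 `COc1cc(OC)c(-c2coc3cc(OCc4ccccc4F)ccc3c2=O)cc1OC`: 1280 nM
- compound 2 `COc1cc(OC)c(-c2coc3cc(OCc4cccc(F)c4)ccc3c2=O)cc1OC`: 1230 nM
- compound 3 `COc1cc(OC)c(-c2coc3cc(OCc4cccc(Cl)c4)ccc3c2=O)cc1OC`: 750 nM

Compound 3, at 750 nM, is not separated from the other two: the data show a 1.7-fold lower number from compound 1 to compound 3 (0.23 log units; within the scatter) and a 1.6-fold lower number from compound 2 to compound 3 (0.21 log units; within the scatter). Compound 4 `COc1cc(OC)c(-c2coc3cc(OCc4ccccc4Cl)ccc3c2=O)cc1OC` carries 2-chlorophenyl in place of 3-chlorophenyl on a saturated chain carbon bound to an oxygen on an aromatic ring. For the measured compounds named here, the closest precedent is the same exchange among the fluoro compounds, read in the opposite direction: a 1.0-fold lower number from compound 1 to compound 2 (0.02 log units; within the scatter). Chloro in place of fluoro gave only a 1.6-fold lower number from compound 2 to compound 3 (0.21 log units; within the scatter). No step beyond the scatter is therefore expected in this assay, and the estimated step is a 1.1-fold higher number from compound 3 to compound 4 (0.05 log units; within the scatter). Compound 4 is expected at 850 nM, with an estimated range of 480 nM to 1450 nM.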

Compound 4, half-maximal inhibitory concentration: 1690 nM
Estimate against measurement, compound 4: 2.0-fold (0.30 log units) below; the whole stated range lies below it.
By their numbers in this assay, from the lowest: compounds 3, 2, 1 and 4 (each within the scatter of the next, the first and the last beyond it).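

In this assay, for the compounds shown here, 2-chlorophenyl in place of 3-chlorophenyl gives the first step beyond the scatter, a 2.3-fold higher number from compound 3 to compound 4 (0.35 log units; beyond the scatter), so the chloro compounds at this place separate where the fluoro pair does not. That separation is limited: compound 4 stays within the scatter of both fluoro compounds, with a 1.4-fold higher number from compound 2 to compound 4 (0.14 log units; within the scatter) and a 1.3-fold higher number from compound 1 to compound 4 (0.12 log units; within the scatter). Chloro in place of fluoro shows no distinct effect between the two attachment patterns: the same change on two cores in this assay, a 1.6-fold lower number (0.21 log units; within the scatter) from compound 2 to compound 3 and a 1.3-fold higher number (0.12 log units; within the scatter) from compound 1 to compound 4, 2.2-fold (0.34 log units) apart, within the scatter of two such steps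

As far as these compounds go, what 3-bromophenyl, 3-methoxyphenyl or unsubstituted phenyl would give at this place stays open. A single modest step also leaves open how firmly the two chloro compounds are separated.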